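A few compounds are considered here, and "the series" means these few. Any claim that something is new, unique, unknown or untested is made for them only; others in the source may bear on it.

Compound 1 `O=C(c1ccc(Cl)cc1)c1cc2c(-c3cccnc3)nn(-c3ccccc3)c2[nH]c1=O` gives 6.45 ug/mL in a functional assay on MCF7 cells (Homo sapiens) for cytotoxicity, read by sulforhodamine B assay; a lower number here means a stronger inhibitor, a higher number a weaker inhibitor. Compound 2 `O=C(c1ccc(F)cc1)c1cc2c(-c3cccnc3)nn(-c3ccccc3)c2[nH]c1=O` gives 8.7 ug/mL.

Among the measured compounds shown here, compound 2 stands at the highest of the two numbers, but its only neighbour, compound 1, lies just a 1.3-fold higher number from compound 1 to compound 2 (0.13 log units; within the scatter) away, a step within the scatter, so the two compounds cannot be told apart on these numbers. Compound 3 `Cc1ccc(C(=O)c2cc3c(-c4cccnc4)nn(-c4ccccc4)c3[nH]c2=O)cc1` has not yet been measured. It differs from compound 2 by methyl in place of fluoro on an aromatic carbon. For the measured compounds named here, the one measured step that bears on this change, the move from chloro to fluoro on the same aromatic carbon, was a 1.3-fold higher number from compound 1 to compound 2 (0.13 log units; within the scatter) and fell within the scatter, so exchanging one group for another at that carbon has so far left the number unchanged. Methyl has no measured counterpart here, which leaves the expectation uncertain, but a step no larger than the scatter is expected, a 1.2-fold lower number from compound 2 to compound 3 (0.06 log units; within the scatter). Compound 3 is therefore expected to give about 7.5 ug/mL, with a likely range of 3.5 ug/mL to 16 ug/mL.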

Compound 3, half-maximal inhibitory concentration: 9.9 ug/mL
Compound 3: middle estimate off by 1.3-fold (0.12 log units), on the low side; the measured number falls inside the stated range.
By their numbers in this assay, from the lowest: compounds 1, 2 and 3 (each within the scatter of the next).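

In this assay, the new compound adds a 1.1-fold higher number from compound 2 to compound 3 (0.06 log units; within the scatter) and a 1.5-fold higher number from compound 1 to compound 3 (0.19 log units; within the scatter), so both steps to methyl stay within the scatter. Until now, only two halogens had been compared at this carbon, para to a large group; with methyl, a group with a carbon atom in that place also leaves compound 1, compound 2 and compound 3 indistinguishable on these numbers. Nothing available explains why these three numbers lie so close together.

From the compounds shown here alone, it remains open whether an amine, a carboxylic acid or a longer chain on this carbon would produce a step beyond the scatter. These three compounds also cannot show whether changes elsewhere on this phenyl ring or on the shared core would be tolerated in the same way.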